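From Ethoxy to Hexyloxy: Estimating Compound 4

The compounds below may be only part of what the source reports. "The series", "measured", "known", "first", "only" and "open" are said of these compounds alone.

Measured compounds in a functional assay on HepG2 cells (Homo sapiens) for cytotoxicity, read by MTT assay, with a stated time of 48 h; a higher number here means a weaker inhibitor, a lower number a stronger inhibitor:
Compound 1, `CCCCCCOc1ccc2c(Cl)ccnc2c1`: 2420 nM
Compound 2, `CCOc1ccc2c(Cl)ccnc2c1`: 2660 nM
Compound 3, `CCOc1ccc2c(NCCN(C)C)ccnc2c1`: 5680 nM

Compound 1 and compound 2 share a core and differ only in the length of the chain on the ring oxygen. The change is butyl in place of hydrogen on a saturated chain carbon, two bonds along the chain from an oxygen on an aromatic ring and in this assay it gave a 1.1-fold lower number from compound 2 to compound 1 (0.04 log units; within the scatter), so the two values cannot be told apart. Compound 3 carries the core of compound 2 with a different group on the aromatic carbon: the difference is (2-(dimethylamino)ethyl)amino in place of chloro on an aromatic carbon, and the step there was a 2.1-fold higher number from compound 2 to compound 3 (0.33 log units; beyond the scatter), which leaves compound 3 with the highest number of the three.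

Compound 4, `CCCCCCOc1ccc2c(NCCN(C)C)ccnc2c1`, is the unmeasured partner of compound 3. Within the data shown here, it differs from compound 3 by butyl in place of hydrogen on a saturated chain carbon, two bonds along the chain from an oxygen on an aromatic ring, the same change as the one from compound 2 to compound 1, made at the same place. Among the measured compounds shown here, the only guide is that earlier step, which was within the scatter, and compound 3 itself with 5680 nM. On that basis compound 4 is expected to show a step of a 1.1-fold lower number from compound 3 to compound 4 (0.03 log units; within the scatter) in this assay, with no real shift either way. The estimate for compound 4 in this assay is therefore 5300 nM, expected to lie between 2500 nM and 11000 nM.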

Compound 4, half-maximal inhibitory concentration: 1370 nM
For compound 4 the middle estimate is 3.9-fold (0.59 log units) above the measured one, and the stated range ends above it.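

In this assay, going from ethoxy to hexyloxy did not carry over from one core to the other: with the (2-(dimethylamino)ethyl)amino group in place it gave a 4.1-fold lower number from compound 3 to compound 4 (0.62 log units; beyond the scatter), whereas with chloro in place it had made no real difference, and the two steps clearly part: the same change on two cores in this assay, a 1.1-fold lower number (0.04 log units; within the scatter) from compound 2 to compound 1 and a 4.1-fold lower number (0.62 log units; beyond the scatter) from compound 3 to compound 4, 3.8-fold (0.58 log units) apart, beyond the scatter of two such steps The exchange of chloro for the (2-(dimethylamino)ethyl)amino group likewise depends on the chain, since with hexyloxy it gave a 1.8-fold lower number from compound 1 to compound 4 (0.25 log units; within the scatter), which stays within the scatter, while with ethoxy it raised the number beyond the scatter: the same change on two cores in this assay, a 2.1-fold higher number (0.33 log units; beyond the scatter) from compound 2 to compound 3 and a 1.8-fold lower number (0.25 log units; within the scatter) from compound 1 to compound 4, 3.8-fold (0.58 log units) apart, beyond the scatter of two such steps Both comparisons rest on the same four compounds, so they show that the two changes do not act independently in this set, but they do not show why, nor whether this holds for any other chain or side chain.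

The compounds shown leave open how the number moves at chain lengths between ethoxy and hexyloxy, such as a butoxy chain, and whether a longer chain than hexyloxy continues the step seen with the (2-(dimethylamino)ethyl)amino group. They also leave open whether another amine in that place, such as a morpholine or a piperidine, would respond to the hexyloxy chain in the same way.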